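Furan-3-yl in place of phenyl on compound 2

The source may report more compounds than this note shows. Statements on the series, on what has been measured and on what is new or still open speak of the compounds shown alone.

Measured in a functional assay on KB 3-1 cells (Homo sapiens) for cytotoxicity, read by MTT assay, with a stated time of 68 h; a higher number here means a weaker inhibitor, a lower number a stronger inhibitor:
Compound 1 `O=C(Nc1cccc(-c2nccs2)c1)C(Cl)Cl`: > 50000 nM
Compound 2 `O=C(Nc1cccc(-c2ccccc2)c1)C(Cl)Cl`: 46800 nM

Compound 1 stands at a limit and not at a number: the limit of > 50000 nM in this assay, at which 1 of the 2 values shown sits. For the measured compounds named here, compound 2 holds the only actual number in this assay. Compound 3 `O=C(Nc1cccc(-c2ccoc2)c1)C(Cl)Cl` carries furan-3-yl in place of phenyl on an aromatic carbon. Going by the values given here, the single measured step, an at least 1.0-fold lower number from compound 1 to compound 2 (0.02 log units; that floor lies within the scatter), also exchanges the group on that aromatic carbon, and it is the only guide available. No step beyond the scatter is therefore expected in this assay, in either direction. The expected step is a 1.0-fold lower number from compound 2 to compound 3 (0.02 log units; within the scatter). For compound 3 the estimate is 45000 nM, with an expected range of 22000 nM to 60000 nM.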

Compound 3, half-maximal inhibitory concentration: > 50000 nM
Compound 3: only a limit was reported (the forecaster's own chance of this, stated with the estimate: 45%); middle value at least 1.1-fold (0.04 log units) from the limit.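

At this position, compound 3 joins compound 1 in giving only a limit in this assay, so two different five-membered aromatic rings, furan-3-yl and 1,3-thiazol-2-yl, now end there: the limit of > 50000 nM in this assay, at which 2 of the 3 values shown sit.

Furan-3-yl in place of phenyl gives an at least 1.0-fold higher number from compound 2 to compound 3 (0.02 log units; that floor lies within the scatter), so the data do not separate these two groups. The step between compound 1 and compound 3 cannot be read, as both values are limits.

Still open, going by these compounds, is whether a different group on this aromatic carbon, such as an amine or a carboxylic acid, moves the number beyond the scatter.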